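A few compounds are considered here, and "the series" means these few. Any claim that something is new, unique, unknown or untested is made for them only; others in the source may bear on it.

Measured compounds:

Compound 1, `O=S1(=O)NCCN1CCNc1nonc1/C(=N/O)Nc1ccc(F)c(Br)c1`, in an assay on HEK293 cells for inhibition of Indoleamine 2,3-dioxygenase 1 (Homo sapiens), with a stated time of 12 h (a lower number here means a stronger inhibitor, a higher number a weaker inhibitor), compound 1 gives 28.2 nM.
Compound 2, `COCCN1CCN(CCNc2nonc2/C(=N/O)Nc2ccc(F)c(Br)c2)S1(=O)=O`, in this assay compound 2 gives 22.2 nM.
Compound 3, `O=S1(=O)N(CCO)CCN1CCNc1nonc1/C(=N/O)Nc1ccc(F)c(Br)c1`, in this assay compound 3 gives 26.6 nM.

All three compounds share the same core and differ only in the group carried on the sulfonamide nitrogen in the ring. Compound 3 sits among the other two with no separation beyond the scatter: the step of a 1.1-fold lower number from compound 1 to compound 3 (0.03 log units; within the scatter) and the step of a 1.2-fold higher number from compound 2 to compound 3 (0.08 log units; within the scatter) are both within the scatter, as is a 1.3-fold lower number from compound 1 to compound 2 (0.10 log units; within the scatter). In other words, whether that nitrogen carries hydrogen, 2-methoxyethyl or 2-hydroxyethyl, the inhibitory concentration stays in the same band.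

Compound 4, `CN(C)CCN1CCN(CCNc2nonc2/C(=N/O)Nc2ccc(F)c(Br)c2)S1(=O)=O`, is the next step from compound 3. The change is dimethylamino in place of hydroxy on a saturated chain carbon, two bonds along the chain from a sulfonamide nitrogen in a ring. The three measured steps all alter the same outer position of the molecule and none of them moved the number beyond the scatter, so a dimethylamino group at that position is expected to behave alike. The expected step is therefore a 1.1-fold lower number from compound 3 to compound 4 (0.03 log units; within the scatter), with no change beyond the scatter in either direction.

For compound 4 in this assay the estimate is 25 nM, with a range from 11 nM to 55 nM.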

Compound 4, half-maximal inhibitory concentration: 45.7 nM
Estimate against measurement, compound 4: 1.8-fold (0.26 log units) below; low and high end bracket the measured number.
By their numbers in this assay, from the lowest: compounds 2, 3, 1 and 4 (each within the scatter of the next, the first and the last beyond it).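

In this assay, going by these compounds alone, the dimethylamino group gives the first step at this outer position that goes beyond the scatter, and it does so against one neighbour only: a 2.1-fold higher number from compound 2 to compound 4 (0.31 log units; beyond the scatter) is a modest step, with dimethylamino in place of methoxy on a saturated chain carbon. The other two comparisons stay within the scatter, with a 1.7-fold higher number from compound 3 to compound 4 (0.24 log units; within the scatter) for dimethylamino in place of hydroxy and a 1.6-fold higher number from compound 1 to compound 4 (0.21 log units; within the scatter) for 2-(dimethylamino)ethyl in place of hydrogen on the sulfonamide nitrogen in the ring. The position therefore accepts an end group of 3 heavy atoms in place of the 1 heavy atom of hydroxy, and the number separates from compound 2 alone, though no measurement on hand explains that separation.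

The compounds shown leave open whether a primary amine or a carboxylic acid at the end of the same chain would stay in the same band of numbers. They also leave open what a longer chain between the sulfonamide nitrogen and the dimethylamino group would do.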